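A few compounds are considered here, and "the series" means these few. Any claim that something is new, unique, unknown or untested is made for them only; others in the source may bear on it.

Compound 3, with the structure `Cc1cc2ccccc2n1CCNC(=O)/C=C/c1ccc(OCCCO)cc1`, gives 5.96 nM in a functional assay on C6 cells for antagonist activity at prostaglandin E2 receptor EP4 subtype (Homo sapiens), read by TR-FRET and cAMP accumulation, with stated times of 10 min and 40 min; a lower number here means a stronger inhibitor, a higher number a weaker inhibitor. That is the lowest of the three numbers in hand, yet its gaps to the other two compounds stay within the scatter of this kind of measurement. Compound 1, `COc1cc(/C=C/C(=O)NCCn2c(C)cc3ccccc32)cc(OC)c1OCCO`, gives 7.49 nM in this assay, and compound 2, `COc1cc(/C=C/C(=O)NCCn2c(C(F)(F)F)cc3ccccc32)cc(OC)c1OCCO`, gives 7.93 nM. Among the measured compounds shown here, the only single-point step that has been measured runs a 1.1-fold higher number from compound 1 to compound 2 (0.02 log units; within the scatter), and it touches the group on the aromatic ring of the shared core, not the chain that ends in a hydroxy group.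

Compound 4, `Cc1cc2ccccc2n1CCNC(=O)/C=C/c1ccc(OCCO)cc1`, is compound 3 with a shorter tail: hydroxy in place of hydroxymethyl on a saturated chain carbon, two bonds along the chain from an oxygen on an aromatic ring. For the measured compounds named here, no measured step mirrors this change directly. Compound 1 and compound 2 both carry the shorter 2-hydroxyethoxy chain, and their numbers sit within the scatter of compound 3, which carries the 3-hydroxypropoxy chain, although those compounds also differ from compound 3 elsewhere. On that footing the change is expected to leave this assay essentially unmoved, with no step beyond the scatter, and the expected step is a 1.2-fold higher number from compound 3 to compound 4 (0.07 log units; within the scatter). Compound 4 is therefore estimated at 7 nM, with a likely range from 3 nM to 16 nM.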

Compound 4, antagonist equilibrium constant: 7.58 nM
Compound 4: the middle estimate sits 1.1-fold (0.03 log units) below what was measured; measured number inside the range.
By their numbers in this assay, from the lowest: compounds 3, 1, 4 and 2 (each within the scatter of the next).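

In this assay, shortening the tail from 3-hydroxypropoxy to 2-hydroxyethoxy gives a 1.3-fold higher number from compound 3 to compound 4 (0.10 log units; within the scatter) and so leaves the number inside the usual noise of the measurement. Among the compounds shown here, this is the first reading of this chain with everything else in the molecule held the same: compound 1 and compound 2 also carry the 2-hydroxyethoxy chain, but each differs from compound 3 in more than one place, so neither could isolate its length. Nothing available accounts for this result.

The compounds shown leave open how far this tolerance extends, as both chains here end in a hydroxy group and differ only by the step between these two lengths, so a longer chain, or a chain ending in a methoxy group, an amine or a carboxylic acid, could behave quite differently. They also leave open whether the same shortening would read the same way on a ring that carries the two methoxy groups of compound 1, where a 3-hydroxypropoxy partner would be needed for a direct comparison.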